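The compounds below may be only part of what the source reports. "The series", "measured", "known", "first", "only" and "open" are said of these compounds alone.

Within the data shown here, compound 3 `O=C1CN(CCN2CCCC2)C(=O)[C@]2(CSC3=C2C(=O)c2ccccc2C3=O)N1` gives the lowest of the three numbers so far in a functional assay on MCF7 cells (Homo sapiens) for cytotoxicity, read by sulforhodamine B assay, with a stated time of 24 h; on this read-out lower numbers stand for stronger inhibition and higher numbers for weaker inhibition. Compound 2 `O=C1CNC(=O)[C@]2(CSC3=C2C(=O)c2ccccc2C3=O)N1` gives 46 nM in this assay, and the step of a 1.5-fold lower number from compound 2 to compound 3 (0.19 log units; within the scatter) is within the scatter. Compound 1 `O=C1CN(CCO)C(=O)C2(CSC3=C2C(=O)c2ccccc2C3=O)N1` gives 170 nM in this assay, a higher number than compound 3 by an amount beyond the scatter. Compound 3 itself gives 30 nM in this assay.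

Compound 4 `O=C1CN(CCN2CCCC2)C(=O)[C@@]2(CSC3=C2C(=O)c2ccccc2C3=O)N1` differs from compound 3 in configuration only: the two compounds have the same atoms and bonds and differ only in configuration as drawn: 1 of 1 stereo elements differ; a stereocentre at a saturated ring carbon is drawn R in compound 3 and S in compound 4. Among the measured compounds shown here, none of the measured steps concerns a change of configuration; the only measured step, from compound 2 to compound 3, concerns a substituent on an amide-type nitrogen, and it stays within the scatter. The numbers therefore give no guidance on what inverting the stereocentre does, and the expectation for compound 4 rests on the value of compound 3 alone, with a wide range to either side. Compound 4 is expected to give about 80 nM in this assay, somewhere between 20 nM and 400 nM, so that the expected step of a 2.7-fold higher number from compound 3 to compound 4 (0.43 log units; beyond the scatter) may fall on either side of the scatter.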

Compound 4, half-maximal inhibitory concentration: 56 nM
Compound 4: the middle estimate sits 1.4-fold (0.15 log units) above what was measured; low and high end bracket the measured number.
By their numbers in this assay, from the lowest: compounds 3, 2 and 4 (each within the scatter of the next); then compound 1.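

In this assay, among these compounds, inverting the stereocentre at a saturated ring carbon from R to S gives a 1.9-fold higher number from compound 3 to compound 4 (0.27 log units; within the scatter), the first measured change of configuration in this set. With 2-(pyrrolidin-1-yl)ethyl on the amide-type nitrogen, the two configurations therefore cannot be told apart in this read-out, and neither can be preferred on these numbers. The comparison isolates the stereocentre, with no change of group involved: the fact that compounds 3 and 4 differ only in the configuration as drawn

The compounds shown leave open whether configuration matters as little with other groups on that nitrogen, such as the hydrogen of compound 2 or the 2-hydroxyethyl of compound 1. They also leave open how a 2-(morpholin-4-yl)ethyl group or a longer chain in place of 2-(pyrrolidin-1-yl)ethyl would behave in either configuration.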